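A few compounds are considered here, and "the series" means these few. Any claim that something is new, unique, unknown or untested is made for them only; others in the source may bear on it.

Measured so far:
compound 1 `O=C1NC(=S)S/C1=C\C=C\c1ccccc1OCc1ccccc1C(F)(F)F` — 80%
compound 2 `O=C1NC(=O)/C(=C/C=C/c2ccccc2OCc2ccccc2Br)S1` — 50%

In a functional assay on DLD-1 cells (Homo sapiens), read by microscopy and crystal violet staining, with a stated time of 20 h, tested at 10 ug/mL (on this read-out lower numbers stand for less inhibition and higher numbers for more inhibition at the one concentration tested (going by the name of the read-out)), compound 1 gives 80%. In this assay compound 2 gives 50%, the lowest of the two numbers; the nearest number is that of compound 1, which stands higher by a gap beyond the scatter. Among the measured compounds shown here, compound 1 and compound 2 differ in more than one place, so no single step between them is counted.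

Compound 3 `O=C1NC(=S)S/C1=C\C=C\c1ccccc1OCc1ccccc1Br` has not yet been measured. It differs from compound 2 by a group of 8 heavy atoms (4 carbon, 1 nitrogen, 1 oxygen, 2 sulfur; one five-membered non-aromatic ring with 2 hetero atoms) in place of a group of 8 heavy atoms (4 carbon, 1 nitrogen, 2 oxygen, 1 sulfur; one five-membered non-aromatic ring with 2 hetero atoms), on a double-bonded chain carbon bound to a double-bonded chain carbon. Compound 1 also carries the group with 1 oxygen and 2 sulfur atoms and gives the higher number, but its other difference from compound 2 leaves that reading uncertain.

For compound 3 in this assay a moderate rise is expected, a step of a number 18 percentage points higher from compound 2 to compound 3 (beyond the scatter). The estimate for compound 3 is 68%, with a range from 45% to 90%.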

Compound 3, a percentage reported as inhibition, at one concentration (the size of the read-out at that concentration, not a potency): 78%
For compound 3 the middle estimate is 10 percentage points below the measured one; the measured number falls inside the stated range.
By their numbers in this assay, from the lowest: compound 2; then compounds 3 and 1 (each within the scatter of the next).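

In this assay, the group with 1 oxygen and 2 sulfur atoms in place of the group with 2 oxygen and 1 sulfur atom, on a double-bonded chain carbon bound to a double-bonded chain carbon, gives a number 28 percentage points higher from compound 2 to compound 3 (beyond the scatter), so this change can now be read on its own with bromo held fixed. Compound 1 and compound 2 could not show this, as they differ in more than one place. With the group carrying 2 sulfur atoms kept, bromo in place of trifluoromethyl on an aromatic carbon gives a number 2 percentage points lower from compound 1 to compound 3 (within the scatter), so this read-out does not separate the two groups at this concentration.

Nothing measured here accounts for the rise. Going by these compounds, it remains open whether the same ring change holds with trifluoromethyl on the aromatic carbon, and whether chloro or methoxy there would give a similar number.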